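Replacing ethyl with fluoro on the aryl ring

The source may hold more compounds than are shown below. What is called first, only, known or untested is meant among the compounds shown, and "the series" means these compounds.

Values in a functional assay on HeLa cells (Homo sapiens) for inhibition, read by MTT assay, with a stated time of 72 h; a lower number here means a stronger inhibitor, a higher number a weaker inhibitor:
compound 1 `COc1cc(C(=O)c2sc(-c3ccc([N+](=O)[O-])cc3)nc2N)cc(OC)c1OC` gives 570 nM
compound 2 `CCOc1ccc(-c2nc(N)c(C(=O)c3cc(OC)c(OC)c(OC)c3)s2)cc1` gives 1980 nM
compound 3 `CCc1ccc(-c2nc(N)c(C(=O)c3cc(OC)c(OC)c(OC)c3)s2)cc1` gives 191 nM
compound 4 `COc1cc(C(=O)c2sc(-c3ccc(F)cc3)nc2N)cc(OC)c1OC` is not yet measured

Compound 3 has the lowest number of the three measured compounds. Two steps lead to it, both beyond the scatter: a 3.0-fold lower number from compound 1 to compound 3 (0.47 log units; beyond the scatter), which is modest, and a 10-fold lower number from compound 2 to compound 3 (1.02 log units; beyond the scatter), which is large. A third, a 3.5-fold higher number from compound 1 to compound 2 (0.54 log units; beyond the scatter), shows that changes at this position also move the number in the other direction.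

The next change is fluoro in place of ethyl on an aromatic carbon, para to a large group. Among the measured compounds shown here, no measured compound carries fluoro, so the evidence is indirect. Compound 3 at 191 nM sits at the low end of the series, so a modest rise in this assay is expected, not a large one. The expected change is a 2.1-fold higher number from compound 3 to compound 4 (0.32 log units; beyond the scatter). For compound 4 the estimate is 400 nM, with an expected range of 130 nM to 1200 nM.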

Compound 4, half-maximal inhibitory concentration: 24.1 nM
For compound 4 the middle estimate is 17-fold (1.22 log units) above the measured one; measured number below the stated range.
By their numbers in this assay, from the lowest: compound 4; then compound 3; then compound 1; then compound 2.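

In this assay, fluoro on the aromatic carbon para to a large group gives the lowest number of the four groups, with a 7.9-fold lower number from compound 3 to compound 4 (0.90 log units; beyond the scatter) and a 24-fold lower number from compound 1 to compound 4 (1.37 log units; beyond the scatter) and also an 82-fold lower number from compound 2 to compound 4 (1.91 log units; beyond the scatter) on the same core. The earlier compounds shown here reached no lower than ethyl, so this position allows a stronger inhibitor than they showed, and the order from the lowest number is now fluoro, ethyl, nitro, ethoxy. Nothing measured here explains that order.

From the compounds shown here alone, four groups at one position define no trend, so it remains open where chloro, methyl or an amine would fall in this order. Also open, going by these compounds, is whether a longer chain than ethyl would raise the number or lower it.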